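A deca-1,4-dien-1-yl chain end on compound 2

The source may report more compounds than this note shows. Statements on the series, on what has been measured and on what is new or still open speak of the compounds shown alone.

In a functional assay on MDA-MB-231 cells (Homo sapiens) for antiproliferative activity, read by MTT assay (on this read-out higher numbers stand for weaker inhibition and lower numbers for stronger inhibition), compound 1 `CCCCC/C=C\C/C=C\CCCCCCCc1cc(=O)c2c(O)c(C)c(OCOC)c(C)c2o1` gives 16100 nM. Compound 2 `CCCCCCCCCCCCCCCc1cc(=O)c2c(O)c(C)c(O)c(C)c2o1` stands at > 87000 nM in this assay, and this is a limit of the assay, not a number. Compound 3 `CCCCC/C=C\C/C=C\CCCCCCCc1cc(=O)c2c(O)c(C)c(O)c(C)c2o1` has not yet been measured. It differs from compound 2 in one place: deca-1,4-dien-1-yl in place of octyl on a saturated chain carbon, seven bonds along the chain from an aromatic carbon.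

Within the data shown here, no measured pair shows what such a change does, so any expectation remains loose. Among the measured compounds shown here, compound 1, at 16100 nM, is the only compound so far with a number, and it suggests that clearly stronger inhibition is reachable. A moderate move towards stronger inhibition is therefore expected in this assay, although the reading could also stay at the limit. The estimated step is an at least 2.7-fold lower number from compound 2 to compound 3 (0.43 log units; beyond the scatter). For compound 3 the expected value is 32000 nM, with an estimated range from 11000 nM to 87000 nM.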

Compound 3, half-maximal inhibitory concentration: 16100 nM
Beside the measured number, compound 3's estimate is 2.0-fold (0.30 log units) above it, and the stated range covers the measured number.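

In this assay, deca-1,4-dien-1-yl in place of octyl on a saturated chain carbon, seven bonds along the chain from an aromatic carbon, gives a real number where the saturated compound gave none, with an at least 5.4-fold lower number from compound 2 to compound 3 (0.73 log units; beyond the scatter). The true size of this step remains unknown because compound 2 sits at a limit of the assay and not at a number: the limit of > 87000 nM in this assay, at which 1 of the 3 values shown sits.
Hydrogen in place of methoxymethyl on an oxygen on an aromatic ring gives no change at the digits printed from compound 1 to compound 3 (within the scatter), so with the deca-1,4-dien-1-yl chain end present, the methoxymethyl group is not needed for this reading.

The compounds shown leave open whether the step belongs to the double bonds of the deca-1,4-dien-1-yl chain end or to its greater length, since both enter together in this one change, and a saturated decyl chain end would separate the two. Also open, on these data alone, is how far the reading would move in this assay with a longer chain, or with an amine or a carboxylic acid at the chain end.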